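The compounds below may be only part of what the source reports. "The series", "measured", "known", "first", "only" and "open" are said of these compounds alone.

Measured so far:
- Compound 1, `Cc1ccc(S(=O)(=O)Nc2cccc(-c3nc(-c4ccc(NC(=O)c5cccnc5)cc4Cl)no3)c2)cc1`: in a functional assay on MDA-MB-231 cells (Homo sapiens) for antiproliferative activity, read by MTT assay, with a stated time of 72 h (on this read-out higher numbers stand for weaker inhibition and lower numbers for stronger inhibition), compound 1 gives > 10000 nM, a limit of the assay.
- Compound 2, `COc1cccc(S(=O)(=O)Nc2cccc(-c3nc(-c4ccc(NC(=O)c5cccnc5)cc4Cl)no3)c2)c1`: compound 2 gives > 10000 nM, again a limit.
- Compound 3, `O=C(Nc1ccccc1)Nc1cccc(-c2nc(-c3ccc(NC(=O)c4cccnc4)cc3Cl)no2)c1`: compound 3 gives > 10000 nM, also a limit.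

Compound 3 thus stands at the same limit as the other two, and no number separates it from them. The three steps, a step that the two limits leave unreadable from compound 1 to compound 2, a step that the two limits leave unreadable from compound 1 to compound 3 and a step that the two limits leave unreadable from compound 2 to compound 3, are all unreadable, since the limit of > 10000 nM in this assay, at which 3 of the 3 values shown sit, leaves no room for a direction or a size. Exchanging the sulfonyl group for a phenylcarbamoyl group on the aromatic nitrogen, or changing the substitution on the sulfonyl aryl, therefore produced nothing that could be read.

Compound 4, `NS(=O)(=O)c1ccc(NC(=O)Nc2cccc(-c3nc(-c4ccc(NC(=O)c5cccnc5)cc4Cl)no3)c2)cc1`, differs from compound 3 by sulfamoyl in place of hydrogen on an aromatic carbon. Going by the values given here, none of the measured steps touches this ring position, and the two that change the group on the same nitrogen are unreadable. Nothing in the shown compounds therefore points to a readable step; the expectation for the step from compound 3 to compound 4 is an at least 1.1-fold lower number from compound 3 to compound 4 (0.04 log units; that floor lies within the scatter), most likely still a limit. For compound 4 the estimate in this assay is 9000 nM, expected within 1500 nM to 40000 nM.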

Compound 4, half-maximal inhibitory concentration: > 10000 nM
Compound 4 ended at the assay's limit; the forecaster's own chance of this, stated with the estimate: 60%; middle value at least 1.1-fold (0.04 log units) away from the limit.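

In this assay compound 4 gives > 10000 nM as a limit of the assay, so the step from compound 3 to compound 4 cannot be read: the limit of > 10000 nM in this assay, at which 4 of the 4 values shown sit.

The compounds shown leave open whether any change to this series gives a value inside the range of the assay.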